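Bromo to Methoxy: Expected Cytotoxicity of Compound 4

The source may report more compounds than this note shows. Statements on the series, on what has been measured and on what is new or still open speak of the compounds shown alone.

Of the compounds shown here, three have so far been measured in an ADME assay on J774 cells (Mus musculus) for cytotoxicity, read by MTT assay, with a stated time of 48 h, tested at 50 ug/mL; on this read-out higher numbers stand for a weaker effect at the one concentration tested and lower numbers for a stronger effect. Compound 1 `O=C(N/N=C/c1ccccc1Br)c1cnccn1` gives 98% in this assay. Compound 2 `O=C(N/N=C/c1ccc(Br)cc1)c1cnccn1` gives 100% in this assay, and compound 3 `COc1ccccc1/C=N/NC(=O)c1cnccn1` gives 97% in this assay. All three numbers lie within the usual scatter of one another, so no order among them can be read from these data.

Compound 2 has the same atoms as compound 1, joined differently; the difference between the two cores is not broken down here. Compound 3 arises from compound 1 by one change, (methoxy in place of bromo on an aromatic carbon), and this change made a step of a number 1 percentage points lower from compound 1 to compound 3 (within the scatter) in this assay.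

Compound 4 `COc1ccc(/C=N/NC(=O)c2cnccn2)cc1` has not yet been measured. It arises from compound 2 by methoxy in place of bromo on an aromatic carbon. Among the compounds with values here, this is the same kind of change as the one from compound 1 to compound 3, though the place differs: in compound 3 the methoxy sits ortho to a large group, in compound 4 para to a large group.

Because the earlier step of a number 1 percentage points lower from compound 1 to compound 3 (within the scatter) stayed within the scatter, the step from compound 2 to compound 4 is expected to be of similar size, estimated at a number 2 percentage points lower from compound 2 to compound 4 (within the scatter) in this assay. Compound 4 is therefore estimated to give 98% in this assay, with an expected range from 88% to 104%.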

Compound 4, a percentage reported as activity, at one concentration (the size of the read-out at that concentration, not a potency): 74%
Compound 4: the middle estimate sits 24 percentage points above what was measured; the whole stated range lies above it.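

In this assay, within the data shown here, methoxy in place of bromo on an aromatic carbon made a step of a number 26 percentage points lower from compound 2 to compound 4 (beyond the scatter), so at the one concentration tested compound 4 shows a stronger effect than compound 2. Set beside the earlier case, the same change did not carry over with the same size from one core to the other: the same change on two cores in this assay, a number 1 percentage points lower (within the scatter) from compound 1 to compound 3 and a number 26 percentage points lower (beyond the scatter) from compound 2 to compound 4, 25 percentage points apart, beyond the scatter of two such steps. Among these compounds, this shows that, in this series, the size of the step seen on one core cannot simply be transferred to another, but with only two pairs it does not show what sets the size, whether the place of the change, with the methoxy of compound 4 para to a large group, or some other difference between the two cores, nor does a reading at a single concentration show how the effect depends on dose.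

The compounds shown carry only bromo or methoxy on the aromatic ring, so they leave open whether the larger step belongs to methoxy alone or would also appear with another group in that place, such as an amine, a carboxylic acid or a longer chain like butoxy. They also leave open whether other changes on the core of compound 2 would differ from those on the core of compound 1 in the same way.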